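Methylation of the carboxamide nitrogen in compound 2

The compounds below may be only part of what the source reports. "The series", "measured", "known", "first", "only" and "open" are said of these compounds alone.

Compound 1 `C[C@H](Nc1c(C(N)=O)nnc2ccc(-c3ccc(OCCCN(C)C)nc3)cc12)c1ccn(C)n1` gives 3.9 nM in an assay on HT-29 cells for inhibition of Serine-protein kinase ATM (Homo sapiens), read by fluorescence, with a stated time of 1 h; on this read-out higher numbers stand for weaker inhibition and lower numbers for stronger inhibition. Compound 2 `Cc1cn(C)nc1[C@H](C)Nc1c(C(N)=O)nnc2ccc(-c3ccc(OCCCN(C)C)nc3)cc12` gives 0.9 nM in this assay, and compound 3 `Cc1cn(C)nc1[C@H](C)Nc1c(C(N)=O)nnc2ccc(-c3ccc(OCCCN4CCCC4)nc3)cc12` gives 0.5 nM. Of the three numbers, compound 2 stands second highest. The step of a 4.3-fold lower number from compound 1 to compound 2 (0.64 log units; beyond the scatter) lies beyond the scatter, whereas the step of a 1.8-fold lower number from compound 2 to compound 3 (0.26 log units; within the scatter) lies within it, so compound 2 and compound 3 cannot be ordered against each other.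

Compound 4 `CNC(=O)c1nnc2ccc(-c3ccc(OCCCN(C)C)nc3)cc2c1N[C@@H](C)c1nn(C)cc1C` has not yet been measured in this assay. It differs from compound 2 by methyl in place of hydrogen on an amide-type nitrogen; the same difference, cut one bond further out, reads amino to methylamino, or carbamoyl to methylcarbamoyl. Neither measured step touches this place: the step from compound 1 to compound 2 concerns an aromatic carbon, and the step from compound 2 to compound 3 concerns the saturated chain carbon. Nothing in the series therefore bears directly on the amide-type nitrogen, and any expectation rests on the lack of precedent rather than on a measured comparison. The expected step is a 3.3-fold higher number from compound 2 to compound 4 (0.52 log units; beyond the scatter), carrying a wide range in either direction. Compound 4 is estimated at 3 nM, with a range from 0.6 nM to 20 nM.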

Compound 4, half-maximal inhibitory concentration: 3.9 nM
For compound 4 the middle estimate is 1.3-fold (0.11 log units) below the measured one, within the range that was stated.
By their numbers in this assay, from the lowest: compounds 3 and 2 (each within the scatter of the next); then compounds 1 and 4 (each within the scatter of the next).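

In this assay, within the data shown here, the amide-type nitrogen proves to be a place the series responds to: the step of a 4.3-fold higher number from compound 2 to compound 4 (0.64 log units; beyond the scatter) for methyl in place of hydrogen lies beyond the scatter and goes towards weaker inhibition, the first measured change at this position. The addition is a single carbon, and inhibition is reduced rather than lost, with compound 4 at 3.9 nM on this read-out, so this nitrogen accepts a methyl at a modest cost. Nothing measured here accounts for the size or direction of this step.

Going by these compounds, whether a longer chain such as ethyl, or a second methyl on the same nitrogen, would move the number further remains open, as does the effect of a carboxylic acid in place of carbamoyl. Also open, on these data alone, is whether methylcarbamoyl carries the same cost alongside the pyrrolidin-1-yl group of compound 3, or on the core of compound 1, which lacks the aromatic methyl.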